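Adding a second chloro to compound 2

This account rests on a few compounds, and the source may have more. Where it says the series, first, only, none or still open, it means among the compounds named here.

- compound 1 `O=S(=O)(/C=C/c1ccc(F)cc1)Cc1ccc(Nc2ncnc3ccccc23)cc1`: 10 nM
- compound 2 `O=S(=O)(/C=C/c1ccc(Cl)cc1)Cc1ccc(Nc2ncnc3ccccc23)cc1`: 49000 nM

Both values come from a functional assay on U-251 cells (Homo sapiens); a higher number here means a weaker inhibitor of growth, a lower number a stronger inhibitor of growth. Among the compounds with values here, compound 2 carries the higher of the two numbers, and compound 1 is its only neighbour. The next structure, compound 3 `O=S(=O)(/C=C/c1ccc(Cl)cc1Cl)Cc1ccc(Nc2ncnc3ccccc23)cc1`, differs from compound 2 by chloro in place of hydrogen on an aromatic carbon. This turns 4-chlorophenyl into 2,4-dichlorophenyl.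

Within the data shown here, only one measured step bears on this change: a 4900-fold higher number from compound 1 to compound 2 (3.69 log units; beyond the scatter). That large step, beyond the scatter, came from chloro in place of fluoro on an aromatic carbon. Among the measured compounds shown here, it is a swap of one halogen for another, not an addition, and no measured compound carries a second halogen. A sizeable step therefore seems possible. The direction is open, although a lower number is somewhat favoured given the high position of compound 2 at 49000 nM.

The expected change is a 6.1-fold lower number from compound 2 to compound 3 (0.79 log units; beyond the scatter). For compound 3 the estimated value in this assay is 8000 nM, with an expected range from 100 nM to 100000 nM.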

Compound 3, concentration for 50% growth inhibition: 4000 nM
Compound 3: the middle estimate sits 2.0-fold (0.30 log units) above what was measured; the measured number falls inside the stated range.
By their numbers in this assay, from the lowest: compound 1; then compound 3; then compound 2.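

In this assay, within the data shown here, the 4-chlorophenyl group of compound 2 proves open to further substitution: a chloro ortho to a large group and meta to the existing chloro group gives a 12-fold lower number from compound 2 to compound 3 (1.09 log units; beyond the scatter), and this is the first step that adds a halogen instead of exchanging one. The recovery is only partial, since the exchange of fluoro for chloro had given a 4900-fold higher number from compound 1 to compound 2 (3.69 log units; beyond the scatter), and the 2,4-dichlorophenyl group still falls well short of the 4-fluorophenyl group, with a 400-fold higher number from compound 1 to compound 3 (2.60 log units; beyond the scatter). Nothing available on these compounds accounts for either the gain from the second chloro or the gap that remains.

Still open, as far as these compounds go, is whether the added chloro acts the same way without the existing chloro group, which a 2-chlorophenyl group would test, and how a plain phenyl group reads against these three. From the compounds shown here alone, it is also open whether fluoro, methyl or methoxy in the place of the added chloro would give a similar step, and whether a second halogen on the 4-fluorophenyl group of compound 1 would move the number up or down.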